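From nitro to amino on the shared core

The compounds below may be only part of what the source reports. "The series", "measured", "known", "first", "only" and "open" are said of these compounds alone.

This account concerns a small set of compounds on one shared core, tested in a functional assay on IMR-32 cells (Homo sapiens) for inhibition, with a stated time of 48 h, tested at 50 uM; on this read-out higher numbers stand for more inhibition of growth at the one concentration tested and lower numbers for less inhibition of growth. In this test compound 3 `C=C[C@@](C)(/C=C/c1ccc(O)c([N+](=O)[O-])c1)CCC=C(C)C` gives 50%. That places it level, within the scatter, with compound 1 `C=C[C@@](C)(/C=C/c1ccc(OC(=O)CCC)cc1)CCC=C(C)C` at 54%. Compound 2 `C=C[C@@](C)(/C=C/c1ccc(OC(=O)CCCCC)cc1)CCC=C(C)C` gives 19%, a lower number lying beyond the scatter from compound 3.

The next compound to be considered is compound 4 `C=C[C@@](C)(/C=C/c1ccc(O)c(N)c1)CCC=C(C)C`, which differs from compound 3 in one place: amino in place of nitro on an aromatic carbon. This aromatic carbon is ortho to a hydroxy group.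

Among the measured compounds shown here, only one measured step is available, a number 35 percentage points lower from compound 1 to compound 2 (beyond the scatter). It is a large step, so the read-out can move substantially within this small set. However, that step lies on a saturated chain, not on an aromatic carbon, and it gives no direct guide to the present change. For the measured compounds named here, no measured pair tests the nitro group or the amino group. The expectation therefore stays close to compound 3, with a wide margin and only a weak lean downward. The expected change is a number 8 percentage points lower from compound 3 to compound 4 (within the scatter). For compound 4 the estimated value is 42%, with an expected range from 18% to 66%.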

Compound 4, percent growth inhibition at one concentration: 39%
Compound 4: the middle estimate sits 3 percentage points above what was measured, within the range that was stated.
By their numbers in this assay, from the lowest: compound 2; then compound 4; then compounds 3 and 1 (each within the scatter of the next).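

Among the compounds shown here, replacing nitro with amino on this aromatic carbon, ortho to a hydroxy group, gives a number 11 percentage points lower from compound 3 to compound 4 (beyond the scatter) and provides the first measured step at a position on the aromatic ring, as the earlier step lay on a saturated chain. The read-out therefore responds to the group on this carbon, though the change is modest and compound 4 still gives 39% at the single concentration tested. No measurement accompanying these compounds accounts for the step, so it remains an observation without an explanation.

The compounds shown leave open whether this step reflects the loss of nitro, the arrival of amino, or both, as this carbon is seen with only these two groups and not with a plain hydrogen, a chlorine, a methoxy group or an acetamide. As far as these compounds go, they also do not show how either group would behave if the neighbouring hydroxy group were replaced by a methoxy group or carried as an ester, and whether the same step would appear there remains unknown.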